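Aminothiophene Ketones: Returning an Aryl Group to the Piperazine

The source may hold more compounds than are shown below. What is called first, only, known or untested is meant among the compounds shown, and "the series" means these compounds.

Compound 1 `COc1ccc(N2CCN(Cc3csc(N)c3C(=O)c3ccc(Cl)cc3)CC2)cc1` is the starting point; in a functional assay on CHO cells with adenosine receptor A1 (Homo sapiens) as the target, read by cAMP accumulation and immunoassay, with a stated time of 6 min, tested at 10 uM (a lower number here means a stronger effect, a higher number a weaker effect of the compound at the concentration tested), compound 1 gives -52%. Compound 2 `Nc1scc(CN2CCN(C3CCCCCC3)CC2)c1C(=O)c1ccc(Cl)cc1` shares the same core and in this assay compound 2 gives -25%. For the measured compounds named here, the one change between them, cycloheptyl in place of 4-methoxyphenyl on an amine nitrogen in a ring, produced a number 27 percentage points higher from compound 1 to compound 2 (beyond the scatter). Of the two measured numbers, compound 2 therefore stands highest, with compound 1 the nearer of its neighbours.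

Compound 3 `Nc1scc(CN2CCN(c3ccc(F)c(Cl)c3)CC2)c1C(=O)c1ccc(Cl)cc1` changes that same position again: 3-chloro-4-fluorophenyl in place of cycloheptyl on an amine nitrogen in a ring. Going by the values given here, only one measured step bears on this, the step from compound 1 to compound 2, which removed an aromatic ring from this nitrogen and was modest in size. Since compound 3 puts an aromatic ring back, the number is expected to move partly back toward compound 1, a step of a number 20 percentage points lower from compound 2 to compound 3 (beyond the scatter). Compound 3 is estimated at -45%, with a range from -70% to -15%.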

Compound 3, a percentage reported as activity, at one concentration (the size of the read-out at that concentration, not a potency): -78%
The estimate for compound 3 lay 33 percentage points above the measured number; measured number below the stated range.
By their numbers in this assay, from the lowest: compound 3; then compound 1; then compound 2.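

Putting an aromatic ring back on this nitrogen does more than reverse the earlier loss: in this assay, the change gives a number 53 percentage points lower from compound 2 to compound 3 (beyond the scatter), a larger step than the one that took an aromatic ring away. The ring's presence is therefore not the whole story, since exchanging one aromatic group for another at the same nitrogen, 3-chloro-4-fluorophenyl for 4-methoxyphenyl, still gives a number 26 percentage points lower from compound 1 to compound 3 (beyond the scatter). Nothing measured here explains why either change moves the number as it does.

The compounds shown do not separate the contributions of the chlorine and the fluorine, which a 3-chlorophenyl or a 4-fluorophenyl group on this nitrogen could begin to do. As far as these compounds go, a plain phenyl group, or a benzyl group, also remains open as a reference point for the aromatic series.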